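The compounds below may be only part of what the source reports. "The series", "measured", "known", "first", "only" and "open" are said of these compounds alone.

Measured so far:
Compound 1, `Cc1cnn(C(=O)N(C)CCN(C)Cc2cccc(OCc3ccccc3)c2)c1`: 4100 nM
Compound 2, `CN(CCN(C)C(=O)n1cccn1)Cc1cccc(OCc2ccccc2)c1`: 4600 nM

Of the compounds shown here, two have been measured in an assay on membranes from brain for binding affinity to Monoglyceride lipase (Mus musculus), read by fluorescence, with stated times of 1 h and 30 min; a higher number here means a weaker inhibitor, a lower number a stronger inhibitor. Compound 1 gives 4100 nM. Compound 2 carries a hydrogen where compound 1 has a methyl on the aromatic carbon, and compound 2 gives 4600 nM. The step of a 1.1-fold higher number from compound 1 to compound 2 (0.05 log units; within the scatter) shows that the two numbers cannot be told apart, so compound 2 stands alongside compound 1 rather than apart from it.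

Compound 3, `CN(CCN(C)C(=O)n1cc(C#N)cn1)Cc1cccc(OCc2ccccc2)c1`, has not yet been measured. It differs from compound 2 by cyano in place of hydrogen on an aromatic carbon, so the same aromatic carbon that carried a methyl in compound 1 and a hydrogen in compound 2 now carries a cyano group.

Within the data shown here, the only measured step that bears on this position is the one from compound 1 to compound 2, and that step lay within the scatter. The data therefore give no sign that this position moves the number much, although a cyano group is a different kind of substituent from a methyl and the data do not cover it. The expected step of a 1.8-fold lower number from compound 2 to compound 3 (0.26 log units; within the scatter) is accordingly a small one, if any. Compound 3 is estimated at 2500 nM, with a range from 500 nM to 9000 nM.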

Compound 3, half-maximal inhibitory concentration: 590 nM
Compound 3: middle estimate off by 4.2-fold (0.63 log units), on the high side; low and high end bracket the measured number.
By their numbers in this assay, from the lowest: compound 3; then compounds 1 and 2 (each within the scatter of the next).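

Cyano on this aromatic carbon of the five-membered aromatic ring gives a 7.8-fold lower number from compound 2 to compound 3 (0.89 log units; beyond the scatter) in this assay and, set against the methyl group, a 6.9-fold lower number from compound 1 to compound 3 (0.84 log units; beyond the scatter) as well. Both steps lie beyond the scatter, so the number does respond to what sits on this carbon, something the swap between methyl and hydrogen gave no sign of with its a 1.1-fold higher number from compound 1 to compound 2 (0.05 log units; within the scatter) alone. Nothing given here speaks to why the cyano group has this effect.

Only three groups on this carbon appear among the compounds shown, so it stays open whether the drop in the number belongs to cyano alone or would also come with chlorine, a primary amide or a carboxylic acid in the same place. All three compounds also share the rest of their structure, which leaves open whether the change from 1H-pyrazol-1-yl to 4-cyano-1H-pyrazol-1-yl would give a step of similar size on a different core.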